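Fluoro on the anilino ring of the trifluoromethyl analogue

A few compounds are considered here, and "the series" means these few. Any claim that something is new, unique, unknown or untested is made for them only; others in the source may bear on it.

Compound 1 `CC(=O)/C(=N\c1ccccc1)NNc1ccccc1C`: 526 nM
Compound 2 `CC(=O)/C(=N\c1cccc(C#N)c1)NNc1ccccc1C`: > 10000 nM
Compound 3 `CC(=O)/C(=N\c1ccccc1)NNc1ccccc1C(F)(F)F`: 2260 nM

In an assay on isolated protein for binding affinity to corticotropin-releasing factor receptor 1 (Homo sapiens) (a lower number here means a stronger inhibitor, a higher number a weaker inhibitor), compound 3 gives 2260 nM, the highest of the two numbers shown; its nearest neighbour is compound 1 with 526 nM, and the step of a 4.3-fold higher number from compound 1 to compound 3 (0.63 log units; beyond the scatter) comes from the change of methyl to trifluoromethyl. For compound 2 the assay reports only a limit, > 10000 nM, with no number (the limit of > 10000 nM in this assay, at which 1 of the 3 values shown sits).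

Compound 4 `CC(=O)/C(=N\c1cccc(F)c1)NNc1ccccc1C(F)(F)F` differs from compound 3 by fluoro in place of hydrogen on an aromatic carbon. Within the data shown here, the only measured step at that position is an at least 19-fold higher number from compound 1 to compound 2 (1.27 log units; beyond the scatter), a large loss on putting cyano in place of hydrogen. Fluoro is a smaller group than cyano, so the step is expected to run in the same direction but to be less severe: a 2.2-fold higher number from compound 3 to compound 4 (0.34 log units; beyond the scatter) is expected. Compound 4 is therefore estimated at 5000 nM in this assay, with a range from 1500 nM to 15000 nM, and a real chance that only a limit is returned.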

Compound 4, inhibition constant: 197 nM
The estimate for compound 4 lay 25-fold (1.40 log units) above the measured number, outside the stated range (below it).
By their numbers in this assay, from the lowest: compound 4; then compound 1; then compound 3. At a limit, above all of these: compound 2.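

In this assay the change from phenyl to 3-fluorophenyl gives an 11-fold lower number from compound 3 to compound 4 (1.06 log units; beyond the scatter), so a substituent on this aromatic carbon can strengthen binding where trifluoromethyl is present on the other ring. The earlier step at this position ran the other way, an at least 19-fold higher number from compound 1 to compound 2 (1.27 log units; beyond the scatter), but there nitrile was the entering group and methyl stood in place of trifluoromethyl, so the two steps form no single trend. Compound 2 gives a limit of the assay and not a number: the limit of > 10000 nM in this assay, at which 1 of the 4 values shown sits.

Going by these compounds, whether fluoro brings a similar gain on compound 1, which carries methyl, stays open, and with it whether the two places act independently. On these data alone, how chloro, methoxy or an amine on the same aromatic carbon would compare with fluoro also stays open.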